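A few compounds are considered here, and "the series" means these few. Any claim that something is new, unique, unknown or untested is made for them only; others in the source may bear on it.

Going by the values given here, compound 1 `Cc1cc(OCCCCCCC[N+]23CCN(CC2)CC3)cc(-n2cc(C(=O)Nc3cc(F)cc(F)c3)c(=O)c3ccc(N(C)C)nc32)c1` is the only member of the series with a number: in an assay on LX2 cells for inhibition of COL1A1 promoter (Homo sapiens), read by a luciferase reporter, with a stated time of 24 h, tested at 50 uM (on this read-out higher numbers stand for a stronger effect at the one concentration tested and lower numbers for a weaker effect), compound 1 gives 5.52%. Compound 2 `CN(C)c1ccc2c(=O)c(C(=O)Nc3cc(F)cc(F)c3)cn(-c3ccc(OCCCCCCC[N+]4(C)CCCC4)cc3Cl)c2n1` carries no number in this assay; compound 2 is reported only as "not active" (no number reported). Compound 3 `Cc1cc(OCCCCCCC[N+]2(C)CCCCC2)cc(-n2cc(C(=O)Nc3cc(F)cc(F)c3)c(=O)c3ccc(N(C)C)nc32)c1` is still to be measured in this assay. Its difference from compound 1 is a group of 7 heavy atoms (6 carbon, 1 nitrogen; one six-membered non-aromatic ring with 1 hetero atom) in place of a group of 8 heavy atoms (6 carbon, 2 nitrogen; 2 six-membered non-aromatic rings with 2 hetero atoms each), on a saturated chain carbon, seven bonds along the chain from an oxygen on an aromatic ring. Among the compounds with values here, no step between measured compounds is known, so nothing sets the size of this one; a change in this assay beyond the usual scatter is not expected in either direction. The expected step is a number 0.5 percentage points lower from compound 1 to compound 3 (within the scatter). Compound 3 is expected to give 5% in this assay, within -6% to 16%.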

Compound 3, a percentage reported as inhibition, at one concentration (the size of the read-out at that concentration, not a potency): 79.7%
The estimate for compound 3 lay 74.7 percentage points below the measured number; measured number above the stated range.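

At the saturated chain carbon, seven bonds along the chain from an oxygen on an aromatic ring, the end group is not a silent position: in this assay, replacing the group with 2 six-membered non-aromatic rings by the group with one such ring gives a number 74.2 percentage points higher from compound 1 to compound 3 (beyond the scatter). Both groups have net charge +1, so that count does not separate the two compounds. No measurement at hand accounts for the step.

As far as these compounds go, whether a trimethylammonium group or a morpholinium ring at this position retains the effect remains open. So does the outcome of a shorter chain carrying the ring of compound 3.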